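Methoxyphenyl ether regiochemistry in the bicyclic amine series

The source may report more compounds than this note shows. Statements on the series, on what has been measured and on what is new or still open speak of the compounds shown alone.

Of the compounds shown here, two carry numbers so far. Compound 1 `COc1cncc(C2=CC3CC(C2)CN(C)C3)c1` gives 0.6 nM in an in vitro assay on SH-EP1 cells for displacement of a labelled ligand from Neuronal acetylcholine receptor; alpha4/beta2 (Homo sapiens); a higher number here means a weaker inhibitor, a lower number a stronger inhibitor. Compound 2 `COc1ccccc1Oc1cncc(C2=CC3CNCC(C2)C3)c1` gives 1 nM in this assay, the higher of the two numbers, yet its gap to compound 1 lies within the scatter, so the two cannot be ranked against each other. Compound 3 `COc1cccc(Oc2cncc(C3=CC4CNCC(C3)C4)c2)c1` has not been measured. It differs from compound 2 by 3-methoxyphenyl in place of 2-methoxyphenyl on an oxygen on an aromatic ring: the same atoms joined differently, 3-methoxyphenyl in place of 2-methoxyphenyl on an oxygen on an aromatic ring. Among the compounds with values here, no measured pair isolates such a change, so the data give no direction for it; the two measured compounds, which differ in several places, nevertheless stay close. The step from compound 2 to compound 3 is expected to be a 1.5-fold higher number from compound 2 to compound 3 (0.18 log units; within the scatter), nothing beyond the scatter. For compound 3 the estimate in this assay is 1.5 nM, with a range from 0.4 nM to 6 nM.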

Compound 3, inhibition constant: 0.9 nM
The estimate for compound 3 lay 1.7-fold (0.22 log units) above the measured number, and the stated range covers the measured number.
By their numbers in this assay, from the lowest: compounds 1, 3 and 2 (each within the scatter of the next).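

In this assay, within the data shown here, 3-methoxyphenyl in place of 2-methoxyphenyl on an oxygen on an aromatic ring gives a 1.1-fold lower number from compound 2 to compound 3 (0.05 log units; within the scatter), and this is the first measured pair that isolates a change at this place. The two compounds cannot be ranked, so this pair shows no preference between 2-methoxyphenyl and 3-methoxyphenyl at this place. No supporting measurement bears on this result.

From the compounds shown here alone, whether a hydroxyl, an amine or a carboxylic acid in place of the methoxy group would also leave the number within the scatter remains open. Going by these compounds, with a single pair at this place, it is also open whether the same exchange would stay as flat on the core of compound 1, which has a methyl group on its ring nitrogen.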